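Adding a phenyl to compound 2

A few compounds are considered here, and "the series" means these few. Any claim that something is new, unique, unknown or untested is made for them only; others in the source may bear on it.

In an ADME assay on Vero cells (Chlorocebus sabaeus) for cytotoxicity, read by sulforhodamine B assay, with a stated time of 72 h (a lower number here means a stronger inhibitor, a higher number a weaker inhibitor), compound 2 (`CN1CCc2cc(O)ccc2C1`) gives > 100000 nM, which is a limit of the assay and not a number. Compound 1 (`CN1Cc2ccc(OCc3ccc(-c4ccccc4)cc3)cc2[C@@H](OCc2ccc(-c3ccccc3)cc2)C1`) gives > 10000 nM, which is also a limit. Going by the values given here, the series therefore holds no measured number so far, and no measured step. Compound 3 (`CN1CCc2cc(Oc3ccccc3)ccc2C1`) has phenyl in place of hydrogen on an oxygen on an aromatic ring of compound 2: phenyl in place of hydrogen on an oxygen on an aromatic ring. Compound 1, though a larger structure, still gives > 10000 nM, a limit, and this points to a modest effect rather than a large one. The expected step of an at least 2.5-fold lower number from compound 2 to compound 3 (0.39 log units; beyond the scatter) is moderate and towards stronger inhibition in this assay, and another reading that is only a limit would be no surprise. For compound 3 the estimated value is 40000 nM, with an expected range of 12000 nM to 130000 nM.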

Compound 3, half-maximal inhibitory concentration: > 100000 nM
Compound 3: no number, only a limit (the forecaster's own chance of this, stated with the estimate: 55%); middle value at least 2.5-fold (0.39 log units) away from the limit.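

The step from compound 2 to compound 3 cannot be read in this assay, as both values are limits of the assay and not numbers. The compounds shown leave open whether phenyl in place of hydrogen on an oxygen on an aromatic ring changes the read-out at all.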